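A few compounds are considered here, and "the series" means these few. Any claim that something is new, unique, unknown or untested is made for them only; others in the source may bear on it.

Compound 1 `CNCC1CCCc2cc(S(=O)(=O)c3ccccc3)ccc21`: 0.316 nM
Compound 2 `N#Cc1cccc(S(=O)(=O)c2ccc3c(c2)CCC[C@H]3C=N)c1`: 0.501 nM
Compound 3 `O=S(=O)(c1cccc(F)c1)c1ccc2c(c1)CCC[C@H]2CN1CC(O)C1`: 0.1 nM

These three compounds share one core and were tested in an assay on isolated protein for displacement of a labelled ligand from 5-hydroxytryptamine receptor 6 (Homo sapiens); on this read-out lower numbers stand for stronger inhibition and higher numbers for weaker inhibition. Compound 3 gives the lowest of the three numbers; compound 1 stands nearest to it and compound 2 furthest, and both gaps lie beyond the usual scatter, so compound 3 is the strongest binder among the measured compounds.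

Compound 4 `CN(C)C(=O)NC[C@@H]1CCCc2cc(S(=O)(=O)c3cccc(F)c3)ccc21` has not yet been measured. It differs from compound 3 in one place: (dimethylcarbamoyl)amino in place of 3-hydroxyazetidin-1-yl on a saturated chain carbon bound to a saturated ring carbon. The 3-hydroxyazetidin-1-yl that leaves carries one four-membered non-aromatic ring with 1 hetero atom, while the (dimethylcarbamoyl)amino that enters has no ring and brings 1 double bond outside aromatic rings. Within the data shown here, no measured pair here shows this same change, so its effect can only be guessed. Since all three measured compounds give low numbers despite different groups at this position, a modest rise is expected for compound 4 in this assay, an estimated step of a 4.0-fold higher number from compound 3 to compound 4 (0.60 log units; beyond the scatter), close to the edge of the scatter. Compound 4 is therefore expected to give about 0.4 nM, with a likely range from 0.1 nM to 1.6 nM.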

Compound 4, inhibition constant: 2.51 nM
Estimate against measurement, compound 4: 6.3-fold (0.80 log units) below; measured number outside the range, above it.
By their numbers in this assay, from the lowest: compound 3; then compounds 1 and 2 (each within the scatter of the next); then compound 4.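

In this assay, replacing 3-hydroxyazetidin-1-yl with (dimethylcarbamoyl)amino on a saturated chain carbon bound to a saturated ring carbon gives a 25-fold higher number from compound 3 to compound 4 (1.40 log units; beyond the scatter) and so shows that this position does not accept every group equally. The earlier compounds shown here differ from one another in more than one place, so they could not show the size of a single change here. No measurement shown explains this large step.

On these data alone, it remains open whether the step comes from losing the ring, from gaining the carbonyl, or from the two together. A dimethylamino group or a pyrrolidine ring in the same place, with the rest of compound 3 unchanged, would help separate these possibilities.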